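Working notes: shortening the hydroxycarbamoyl chain in one series

The source may hold more compounds than are shown below. What is called first, only, known or untested is meant among the compounds shown, and "the series" means these compounds.

Compound 1 `C=CC(=O)Nc1cc2c(Nc3ccc(OCc4cccc(F)c4)c(Cl)c3)ncnc2cc1OCc1cn(CCCCC(=O)NO)nn1` gives 18800 nM in a functional assay on A-431 cells (Homo sapiens) for antiproliferative activity, read by MTT assay, with a stated time of 72 h; on this read-out higher numbers stand for weaker inhibition and lower numbers for stronger inhibition.
Compound 2 `C=CC(=O)Nc1cc2c(Nc3cccc(Cl)c3F)ncnc2cc1OCc1cn(CCCCC(=O)NO)nn1` gives 15600 nM in this assay.
Compound 3 `C=CC(=O)Nc1cc2c(Nc3ccc(OCc4cccc(F)c4)c(Cl)c3)ncnc2cc1OCc1cn(CCC(=O)NO)nn1` gives 16300 nM in this assay.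

Compound 4 `C=CC(=O)Nc1cc2c(Nc3cccc(Cl)c3F)ncnc2cc1OCc1cn(CCC(=O)NO)nn1` is the remaining member of the set and has not yet been measured in this assay.

Compound 1 and compound 3 share the same core and differ only at the chain end; the change is hydroxycarbamoyl in place of 2-(hydroxycarbamoyl)ethyl on a saturated chain carbon, two bonds along the chain from an aromatic nitrogen. The step this change made is a 1.2-fold lower number from compound 1 to compound 3 (0.06 log units; within the scatter), so within this pair the shorter chain and the longer chain cannot be told apart on the read-out.

Compound 2 differs from compound 1 in a larger part of the molecule; the difference between the two cores is not broken down here. The values of compound 2, compound 1 and compound 3 all lie within the scatter of each other, so no ordering among the three measured compounds is supported.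

Going by the values given here, compound 4 is related to compound 2 by hydroxycarbamoyl in place of 2-(hydroxycarbamoyl)ethyl on a saturated chain carbon, two bonds along the chain from an aromatic nitrogen, the same change as the one made from compound 1 to compound 3, at the same place. The step from compound 2 to compound 4 is expected to be a 1.1-fold lower number from compound 2 to compound 4 (0.05 log units; within the scatter), and this expectation rests on a 1.2-fold lower number from compound 1 to compound 3 (0.06 log units; within the scatter). The estimate for compound 4 is therefore 14000 nM, with a plausible range from 7000 nM to 28000 nM; all values in this set are weak on this read-out, and compound 4 is expected to remain so.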

Compound 4, half-maximal inhibitory concentration: 15000 nM
Estimate against measurement, compound 4: 1.1-fold (0.03 log units) below; the measured number falls inside the stated range.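

On the core of compound 2, the change from 2-(hydroxycarbamoyl)ethyl to hydroxycarbamoyl gives a 1.0-fold lower number from compound 2 to compound 4 (0.02 log units; within the scatter) in this assay, so the two chain lengths cannot be told apart on this core, as on the core of compound 1. The two steps do not differ: the same change on two cores in this assay, a 1.2-fold lower number (0.06 log units; within the scatter) from compound 1 to compound 3 and a 1.0-fold lower number (0.02 log units; within the scatter) from compound 2 to compound 4, 1.1-fold (0.04 log units) apart, within the scatter of two such steps

This shows that the absence of a readable step carries from one core to the other in this assay, but since both steps lie within the scatter, it does not show that any real effect of the change has been transferred, and it covers only these two cores and this one read-out.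

The compounds shown leave open whether a longer chain than 4-(hydroxycarbamoyl)butyl, or a shorter one such as (hydroxycarbamoyl)methyl, would give a readable step on either core. They also leave open whether a carboxylic acid or a primary amide at the chain end, in place of the hydroxycarbamoyl group, would separate from the values seen here, and whether the two cores would still behave alike with such a group.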